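Swapping trifluoromethyl for cyano on a sulfonamide series

The source may hold more compounds than are shown below. What is called first, only, known or untested is meant among the compounds shown, and "the series" means these compounds.

Three compounds were measured in a functional assay on MDA-MB-231 cells (Homo sapiens) for antiproliferative activity, read by MTT assay, with a stated time of 24 h; a lower number here means a stronger inhibitor, a higher number a weaker inhibitor:

Compound 1, `N#Cc1ccc(S(=O)(=O)NC(CC(=O)O)c2ccccc2F)cc1`, gives 69700 nM.
Compound 2, `O=C(O)CC(NS(=O)(=O)c1ccc(C(F)(F)F)cc1)c1ccccc1F`, gives 47100 nM.
Compound 3, `O=C(O)CC(NS(=O)(=O)c1ccc(C(F)(F)F)cc1)c1ccc(Cl)cc1Cl`, gives 30400 nM.

The change cyano in place of trifluoromethyl on an aromatic carbon has been measured once: a 1.5-fold higher number from compound 2 to compound 1 (0.17 log units; within the scatter). The same change now leads from compound 3 to compound 4, `N#Cc1ccc(S(=O)(=O)NC(CC(=O)O)c2ccc(Cl)cc2Cl)cc1`: cyano in place of trifluoromethyl on an aromatic carbon. The two cores differ in this way: 2,4-dichlorophenyl in place of 2-fluorophenyl on a saturated chain carbon bound to a saturated chain carbon and a sulfonamide nitrogen, with a 1.5-fold lower number from compound 2 to compound 3 (0.19 log units; within the scatter).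

Because the earlier step of a 1.5-fold higher number from compound 2 to compound 1 (0.17 log units; within the scatter) is small, compound 4 is expected to sit close to compound 3, with a step of about a 1.5-fold higher number from compound 3 to compound 4 (0.17 log units; within the scatter) in this assay. A single prior example is a thin basis, so the range is kept wide. Compound 4 is therefore estimated at 45000 nM, between 20000 nM and 100000 nM.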

Compound 4, half-maximal inhibitory concentration: 12600 nM
Compound 4: the middle estimate sits 3.6-fold (0.55 log units) above what was measured, and the stated range ends above it.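

Putting cyano in place of trifluoromethyl gave a 2.4-fold lower number from compound 3 to compound 4 (0.38 log units; beyond the scatter) in this assay on the 2,4-dichlorophenyl core, so the step seen on the 2-fluorophenyl core did not carry over unchanged: (the same change on two cores in this assay, a 1.5-fold higher number (0.17 log units; within the scatter) from compound 2 to compound 1 and a 2.4-fold lower number (0.38 log units; beyond the scatter) from compound 3 to compound 4, 3.6-fold (0.55 log units) apart, beyond the scatter of two such steps). Read the other way, changing 2-fluorophenyl to 2,4-dichlorophenyl gave a 5.5-fold lower number from compound 1 to compound 4 (0.74 log units; beyond the scatter) with cyano in place, and the size of that step also depended on its partner group: (the same change on two cores in this assay, a 1.5-fold lower number (0.19 log units; within the scatter) from compound 2 to compound 3 and a 5.5-fold lower number (0.74 log units; beyond the scatter) from compound 1 to compound 4, 3.6-fold (0.55 log units) apart, beyond the scatter of two such steps). This shows that the two changes are not independent in these four compounds, but it does not show why, or how either change would behave on any other core.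

From the compounds shown here alone, it remains open how a core carrying an amine or a methoxy group on the phenyl ring would respond to the same swap. Also open, going by these compounds, is how an amide in place of cyano would compare.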